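This account rests on a few compounds, and the source may have more. Where it says the series, first, only, none or still open, it means among the compounds named here.

Compound 1, `COc1ccc(OC)c(Sc2ccc3nnc(-c4ccccc4)n3n2)c1`: 1380 nM in an assay on HEK293 cells for inhibition of Leucine-rich repeat serine/threonine-protein kinase 2 (Homo sapiens), read by ELISA, with a stated time of 90 min; on this read-out lower numbers stand for stronger inhibition and higher numbers for weaker inhibition. Compound 2, `COc1ccc(OC)c(Sc2ccc3nnc(-c4ccccn4)n3n2)c1`: 1310 nM in this assay.

Compound 2 and compound 1 sit within the scatter of each other, the step of a 1.1-fold lower number from compound 1 to compound 2 (0.02 log units; within the scatter) being too small to count as a change. Compound 3, `COc1ccc(OC)c(Sc2ccc3nnc(-c4cccnc4)n3n2)c1`, differs from compound 2 only in that (pyridin-3-yl in place of pyridin-2-yl on an aromatic carbon). Going by the values given here, the one measured step that bears on this, a 1.1-fold lower number from compound 1 to compound 2 (0.02 log units; within the scatter), shows that exchanging the ring at this same carbon left the number essentially unchanged. Compound 3 is therefore expected to show a 1.0-fold lower number from compound 2 to compound 3 (0.00 log units; within the scatter), nothing beyond the scatter. The estimate for compound 3 is 1300 nM, with a range from 500 nM to 3500 nM.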

Compound 3, half-maximal inhibitory concentration: 736 nM
Compound 3: the middle estimate sits 1.8-fold (0.25 log units) above what was measured; the range from low to high includes it.
By their numbers in this assay, from the lowest: compounds 3, 2 and 1 (each within the scatter of the next).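

In this assay the place of the ring nitrogen can now be judged as well as its presence: pyridin-3-yl in place of pyridin-2-yl gives a 1.8-fold lower number from compound 2 to compound 3 (0.25 log units; within the scatter) and pyridin-3-yl in place of phenyl gives a 1.9-fold lower number from compound 1 to compound 3 (0.27 log units; within the scatter) at this same carbon. All three aromatic rings thus stay within the scatter of one another, so neither change moves the number measurably. On these data alone, whether an amine, a carboxylic acid or a longer chain at this carbon would shift the number stays open. Nothing at hand gives a reason for these numbers.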